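The source may hold more compounds than are shown below. What is called first, only, known or untested is meant among the compounds shown, and "the series" means these compounds.

Three related compounds have been tested so far in a functional assay on HCT-116 cells (Homo sapiens) for antiproliferative activity; a higher number here means a weaker inhibitor, a lower number a stronger inhibitor. Compound 1 `CC(=O)N1CCc2c(C)c3c(n2-c2ccc(C(N)=O)c(c2)N[C@@H](C)[C@H](C)C1)CC(C)(C)CC3=O` gives 24 nM and compound 3 `COCCC(=O)N1CCCc2c(C)c3c(n2-c2ccc(C(N)=O)c(c2)N[C@@H](C)[C@@H]1C)CC(C)(C)CC3=O` gives 55 nM. Compound 2 `Cc1c2c(n3c1CCN(C(=O)CN)C[C@@H](C)[C@H](C)Nc1cc-3ccc1C(N)=O)CC(C)(C)CC2=O` gives 216 nM, the highest number of the three, which makes it the weakest inhibitor of this small set.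

Compound 4 `COCCC(=O)N1CCc2c(C)c3c(n2-c2ccc(C(N)=O)c(c2)N[C@@H](C)[C@H](C)C1)CC(C)(C)CC3=O` keeps the core of compound 2 and alters one group: methoxymethyl in place of amino on a saturated chain carbon bound to a carbonyl carbon. In words, this puts methoxymethyl in place of amino on a saturated chain carbon bound to a carbonyl carbon.

Among the compounds with values here, the one measured step that bears directly on this change is a 9.0-fold higher number from compound 1 to compound 2 (0.95 log units; beyond the scatter), where amino took the place of hydrogen on that same carbon. Compound 4 loses that amino group, though methoxymethyl is not hydrogen, so only part of that step may be undone. Compound 3, which carries the same (2-methoxyethyl)carbonyl group on a different core, gives 55 nM, and this also points to a lower number.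

The expected change, beyond the scatter and toward a stronger inhibitor, is a 5.4-fold lower number from compound 2 to compound 4 (0.73 log units; beyond the scatter). For compound 4 the estimate is 40 nM, with an expected range from 15 nM to 100 nM.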

Compound 4, half-maximal inhibitory concentration: 38 nM
Estimate against measurement, compound 4: 1.1-fold (0.02 log units) above, within the range that was stated.
By their numbers in this assay, from the lowest: compounds 1, 4 and 3 (each within the scatter of the next, the first and the last beyond it); then compound 2.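

In this assay, methoxymethyl in place of amino on a saturated chain carbon bound to a carbonyl carbon gives a 5.7-fold lower number from compound 2 to compound 4 (0.75 log units; beyond the scatter), so the weak result of compound 2 does not extend to every group at this place. Methoxymethyl in place of hydrogen on that same carbon gives a 1.6-fold higher number from compound 1 to compound 4 (0.20 log units; within the scatter), so of the three groups seen here, only amino separates itself from the others. No measurement shown here explains the difference between amino and methoxymethyl.

On these data alone, it remains open whether a carboxylic acid on this carbon, or a longer chain ending in an amine, would follow amino or methoxymethyl. A hydroxyl group in place of amino would help show whether the amino nitrogen itself matters.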